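This account rests on a few compounds, and the source may have more. Where it says the series, first, only, none or still open, it means among the compounds named here.

Of the compounds shown here, two built on the same core have been tested in a functional assay on KB cells (Homo sapiens) for antiproliferative activity, read by sulforhodamine B assay, with a stated time of 3 days; on this read-out lower numbers stand for an effect already at smaller amounts and higher numbers for an effect only at larger amounts of compound. Compound 1 `CCCOc1ccc(-c2cc(=O)c3c(o2)C(CC)(CC)C(=O)C(CC)=C3O)cc1` reaches only a limit of the assay, not a number: in this assay compound 1 shows > 50.5 uM, which is the limit of > 50.5 uM in this assay, at which 1 of the 2 values shown sits. Going by the values given here, compound 2 `CCC1=C(O)c2c(oc(-c3ccccc3OC)cc2=O)C(CC)(CC)C1=O` is the one compound here with an actual number: in this assay compound 2 gives 40.8 uM. Among the compounds with values here, compound 2 therefore stands as the only measured value, the other result being a limit. Within the data shown here, no two measured compounds differ in a single place, so no measured step between them can be drawn.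

Compound 3 `CCC1=C(O)c2c(oc(-c3cc(C)cc(C)c3)cc2=O)C(CC)(CC)C1=O` has not yet been measured. It differs from compound 2 in one place: 3,5-dimethylphenyl in place of 2-methoxyphenyl on an aromatic carbon. Neither compound 1 nor compound 2 shows a strong effect, and nothing among them tells which way this exchange will turn. In this assay the expected step is a 1.2-fold lower number from compound 2 to compound 3 (0.07 log units; within the scatter), small and not clearly beyond the scatter in either direction. Compound 3 is estimated at 35 uM, within a range from 12 uM to 100 uM, and a limit rather than a number is a real possibility.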

Compound 3, concentration for half-maximal effect: 45.5 uM
The estimate for compound 3 lay 1.3-fold (0.11 log units) below the measured number, and the stated range covers the measured number.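

In this assay, going by these compounds alone, replacing 2-methoxyphenyl with 3,5-dimethylphenyl on this aromatic carbon gives a 1.1-fold higher number from compound 2 to compound 3 (0.05 log units; within the scatter), the first step that can be read at this position. The exchange removes the one hydrogen-bond acceptor of the leaving group and keeps the count of 8 heavy atoms, yet the two compounds cannot be told apart in this measurement, so this particular exchange gives no sign that the position matters. Within the data shown here, compound 1 still stands at a limit of the assay, not at a number, so no step to it can be read: the limit of > 50.5 uM in this assay, at which 1 of the 3 values shown sits.

The groups at this position in all three compounds are six-membered aromatic rings of carbon only, which leaves open what an amine or a carboxylic acid on that ring, or a longer alkyl chain in its place, would do to the number. From the compounds shown here alone, it also remains open whether any exchange at this position can move the number beyond the scatter, and what, if anything, would bring these compounds to a strong effect.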